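The source may hold more compounds than are shown below. What is called first, only, known or untested is meant among the compounds shown, and "the series" means these compounds.

Measured so far in an ADME assay on K562 cells (Homo sapiens) for cytotoxicity, with a stated time of 72 h (on this read-out higher numbers stand for weaker inhibition and lower numbers for stronger inhibition), are these compounds:
- compound 1 `Oc1cccc(CNc2ncnc3c2ncn3C2CCCCO2)c1` with 81000 nM
- compound 2 `COc1ccccc1CNc1ncnc2c1ncn2C1CCCCO1` with 97000 nM
- compound 3 `COc1cccc(CNc2ncnc3c2ncn3C2CCCCO2)c1` with 61000 nM

Compound 3 lies within the scatter of both other compounds (a 1.3-fold lower number from compound 1 to compound 3 (0.12 log units; within the scatter) and a 1.6-fold lower number from compound 2 to compound 3 (0.20 log units; within the scatter)), and the third pair is no different (a 1.2-fold higher number from compound 1 to compound 2 (0.08 log units; within the scatter)), so the three values cannot be ranked.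

Next is compound 4 `COc1ccc(OC)c(CNc2ncnc3c2ncn3C2CCCCO2)c1`, which differs from compound 3 by methoxy in place of hydrogen on an aromatic carbon in the form of methoxy in place of hydrogen on an aromatic carbon, ortho to a large group and para to a methoxy group. The nearest evidence is the swap of 2-methoxyphenyl for 3-methoxyphenyl (a 1.6-fold lower number from compound 2 to compound 3 (0.20 log units; within the scatter)) and the methyl in place of hydrogen on the oxygen (a 1.3-fold lower number from compound 1 to compound 3 (0.12 log units; within the scatter)). Both stay within the scatter. Going by the values given here, no measured compound carries a second methoxy, so the addition itself is untested.

For this addition no step beyond the scatter is expected in this assay (a 1.1-fold higher number from compound 3 to compound 4 (0.06 log units; within the scatter)). Compound 4 is estimated at 70000 nM with an expected range from 38000 nM to 125000 nM (an estimate, not a measurement).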

Compound 4, half-maximal inhibitory concentration: 16500 nM
The estimate for compound 4 lay 4.2-fold (0.63 log units) above the measured number, outside the stated range (below it).
By their numbers in this assay, from the lowest: compound 4; then compounds 3, 1 and 2 (each within the scatter of the next).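

In this assay, methoxy in place of hydrogen on an aromatic carbon, ortho to a large group and para to a methoxy group, gives a 3.7-fold lower number from compound 3 to compound 4 (0.57 log units; beyond the scatter), a modest step beyond the scatter. Adding a methoxy to the other single-methoxy ring gives a 5.9-fold lower number from compound 2 to compound 4 (0.77 log units; beyond the scatter), so in these two pairs a second methoxy on the ring moves the number past the scatter, which no step among the three earlier compounds did. Nothing measured here accounts for this shift.

On these data alone, only one two-methoxy pattern appears, so it remains open whether the step depends on this position or on the presence of a second methoxy anywhere on the ring. Also open, as far as these compounds go, is whether ethoxy, fluorine or an amine on the same carbon would give a similar step.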